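Cyclopropyl for Ethyl on a Quinolone-Bearing Hybrid

The source may report more compounds than this note shows. Statements on the series, on what has been measured and on what is new or still open speak of the compounds shown alone.

Measured compounds:
compound 1 `COc1cc(Cc2cnc(/N=C3\C(=O)N(CN4CCCCC4C)c4ccc(Cl)cc43)nc2N)cc(OC)c1OC` — > 83.8 ug/mL
compound 2 `CCn1cc(C(=O)O)c(=O)c2cc(F)c(N3CCN(CN4C(=O)/C(=N\c5ncc(Cc6cc(OC)c(OC)c(OC)c6)c(N)n5)c5cc(Cl)ccc54)C(C)C3)c(F)c21` — 18.7 ug/mL
compound 3 `COc1cc(Cc2cnc(/N=C3\C(=O)N(CN4CCN(C)CC4)c4ccc(Cl)cc43)nc2N)cc(OC)c1OC` — 88 ug/mL

Of the compounds shown here, three have been tested in an ADME assay on CCRF-CEM cells (Homo sapiens) for cytotoxicity, read by MTT assay, with a stated time of 5 days; a higher number here means that more compound is tolerated, a lower number that less compound is tolerated. For compound 1 the result is only a limit of the assay, > 83.8 ug/mL, and not a number (the limit of > 83.8 ug/mL in this assay, at which 1 of the 3 values shown sits). Compound 3 gives 88 ug/mL in this assay. Compound 2 gives 18.7 ug/mL in this assay, the lowest of the two numbers; compound 3 stands above it by a gap beyond the usual scatter. For the measured compounds named here, the only step between measured compounds that differ in one place, a step that the limit leaves unreadable from compound 1 to compound 3, cannot be read because one end is a limit.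

Compound 4 `COc1cc(Cc2cnc(/N=C3\C(=O)N(CN4CCN(c5c(F)cc6c(=O)c(C(=O)O)cn(C7CC7)c6c5F)CC4C)c4ccc(Cl)cc43)nc2N)cc(OC)c1OC` differs from compound 2 by cyclopropyl in place of ethyl on an aromatic nitrogen. Going by the values given here, none of the measured steps touches this kind of change, and the one step recorded is unreadable, so there is no measured ground for expecting a shift in either direction. Compound 4 is therefore expected to sit close to compound 2, with a 1.1-fold higher number from compound 2 to compound 4 (0.03 log units; within the scatter) as the expected step, within the scatter. The estimate for compound 4 in this assay is 20 ug/mL, with a likely range from 8 ug/mL to 50 ug/mL.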

Compound 4, half-maximal cytotoxic concentration: 67 ug/mL
For compound 4 the middle estimate is 3.4-fold (0.53 log units) below the measured one, and the stated range ends below it.
By their numbers in this assay, from the lowest: compound 2; then compounds 4 and 3 (each within the scatter of the next).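

For the compounds shown here, the substituent on this aromatic nitrogen turns out not to be silent in this assay: a 3.6-fold higher number from compound 2 to compound 4 (0.55 log units; beyond the scatter) is the first readable step, and it is a step towards more compound being tolerated. Going by these compounds alone, the earlier compounds could not show this, since none of them varied this position and their only step, on the other side of the molecule, cannot be read. Ethyl and cyclopropyl carry neither hydrogen-bond donors or acceptors nor a net charge, so the change is one of a small carbon group for a three-membered ring of carbon, yet nothing shown here accounts for the size of the step.

On these data alone, this is a single pair, so it sets no trend for the position, and it remains open whether a propyl chain, a tert-butyl group or a phenyl ring on the same nitrogen would move the number further or bring it back towards that of compound 2. Also open, as far as these compounds go, is whether the step would survive with an amide in place of the carboxy group on that ring.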